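The source may hold more compounds than are shown below. What is called first, only, known or untested is meant among the compounds shown, and "the series" means these compounds.

Compound 3 `Cc1cccc(NC(=O)N[C@H]2CC[C@H](Oc3ccc(F)cc3)CC2)c1` gives 14400 nM in a functional assay on CRL2813 cells (Homo sapiens) for cytotoxicity, read by sulforhodamine B assay, with a stated time of 5 days (a lower number here means a stronger inhibitor, a higher number a weaker inhibitor), the second highest of the three numbers recorded, nearest to compound 2 `O=C(Nc1ccc(F)cc1)N[C@H]1CC[C@H](Oc2ccc(F)cc2)CC1`, which gives 20000 nM, and furthest from compound 1 `O=C(Nc1ccc(I)cc1)N[C@H]1CC[C@H](Oc2ccc(F)cc2)CC1`, which gives 10200 nM. Compound 4 `O=C(Nc1ccccc1Br)N[C@H]1CC[C@H](Oc2ccc(F)cc2)CC1` differs from compound 3 by 2-bromophenyl in place of 3-methylphenyl on an amide-type nitrogen. The measured steps that bear on this exchange of the aryl group on the amide-type nitrogen are a 1.4-fold higher number from compound 1 to compound 3 (0.15 log units; within the scatter) and a 1.4-fold lower number from compound 2 to compound 3 (0.14 log units; within the scatter), both within the scatter, and a 2.0-fold higher number from compound 1 to compound 2 (0.29 log units; within the scatter) likewise stays within it. On that record, compound 4 is expected to show no step beyond the scatter in this assay, a 1.0-fold lower number from compound 3 to compound 4 (0.01 log units; within the scatter). Compound 4 is therefore estimated at 14000 nM, within a range of 5000 nM to 40000 nM.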

Compound 4, half-maximal inhibitory concentration: 7700 nM
For compound 4 the middle estimate is 1.8-fold (0.26 log units) above the measured one, within the range that was stated.
By their numbers in this assay, from the lowest: compounds 4, 1, 3 and 2 (each within the scatter of the next, the first and the last beyond it).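

In this assay the exchange of aryl groups on the amide-type nitrogen now gives its first step beyond the scatter, a modest one: a 2.6-fold lower number from compound 2 to compound 4 (0.41 log units; beyond the scatter), with 2-bromophenyl in place of 4-fluorophenyl. The other two exchanges remain within the scatter: a 1.9-fold lower number from compound 3 to compound 4 (0.27 log units; within the scatter) and a 1.3-fold lower number from compound 1 to compound 4 (0.12 log units; within the scatter), so among these four compounds only compound 2 and compound 4 are separated. No measurement on hand accounts for that step. Going by these compounds, whether an amine or a carboxylic acid on this aryl ring would move the number further remains open, as does the effect of a longer chain in its place.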